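Working notes: from compound 3 to compound 4

A few compounds are considered here, and "the series" means these few. Any claim that something is new, unique, unknown or untested is made for them only; others in the source may bear on it.

- compound 1 `CC1(Cc2ccc(/C(N)=N/O)cc2)CC(S(=O)(=O)c2ccc(F)cc2)=C(c2ccc(/C(N)=N/O)cc2)O1`: 42200 nM
- compound 2 `CC1(Cc2cccc(C(F)(F)F)c2)CC(S(=O)(=O)c2ccc(F)cc2)=C(c2ccc(/C(N)=N/O)cc2)O1`: 49800 nM
- compound 3 `CC1(Cc2ccc(-c3ccccc3)cc2)CC(S(=O)(=O)c2ccc(F)cc2)=C(c2ccc(/C(N)=N/O)cc2)O1`: 33900 nM

The values above come from an ADME assay on cells (Peritoneal macrophage, Mus musculus, strain Balb/c) for cytotoxicity, read by resazurin assay, with a stated time of 72 h; on this read-out higher numbers stand for lower toxicity in this test and lower numbers for higher toxicity in this test. There, compound 3 gives 33900 nM, which lies within the scatter of both other measured compounds. The next compound is compound 4 `CC1(Cc2ccccc2Br)CC(S(=O)(=O)c2ccc(F)cc2)=C(c2ccc(/C(N)=N/O)cc2)O1`, which differs from compound 3 as follows: 2-bromophenyl in place of 4-phenylphenyl on a saturated chain carbon bound to a saturated ring carbon. The change is 2-bromophenyl in place of 4-phenylphenyl on a saturated chain carbon bound to a saturated ring carbon.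

Two measured steps fall at this same place: a 1.2-fold higher number from compound 1 to compound 2 (0.07 log units; within the scatter) and a 1.5-fold lower number from compound 2 to compound 3 (0.17 log units; within the scatter). A third step, at an aromatic carbon, is a 1.2-fold lower number from compound 1 to compound 3 (0.10 log units; within the scatter). All three stay within the scatter, so no step beyond the scatter is expected in this assay. For the measured compounds named here, no measured compound carries 2-bromophenyl, which leaves the expectation open to some error. The expected change is a 1.2-fold higher number from compound 3 to compound 4 (0.07 log units; within the scatter). For compound 4 the estimated value is 40000 nM, with an expected range from 22000 nM to 72000 nM.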

Compound 4, half-maximal cytotoxic concentration: 109000 nM
For compound 4 the middle estimate is 2.7-fold (0.44 log units) below the measured one; measured number outside the range, above it.
By their numbers in this assay, from the lowest: compounds 3, 1 and 2 (each within the scatter of the next); then compound 4.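

At the saturated chain carbon bound to a saturated ring carbon, a change of group now moves the number in this assay beyond the scatter: a 3.2-fold higher number from compound 3 to compound 4 (0.51 log units; beyond the scatter), a 2.2-fold higher number from compound 2 to compound 4 (0.34 log units; beyond the scatter) and a 2.6-fold higher number from compound 1 to compound 4 (0.41 log units; beyond the scatter). All three steps are modest and run the same way, toward lower toxicity in this test, so 2-bromophenyl stands apart from the three other groups at this place, whose compounds remain within the scatter of one another. No available evidence accounts for this separation.

From the compounds shown here alone, it remains open whether the step belongs to the bromine itself or to 2-bromophenyl as a whole, a question on which 2-chlorophenyl or 4-bromophenyl at this place would bear. Also open, going by these compounds, is whether a group without an aromatic ring, such as an amine chain, would keep the number at this level.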